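A few compounds are considered here, and "the series" means these few. Any claim that something is new, unique, unknown or untested is made for them only; others in the source may bear on it.

Compound 1: `O=C1c2ccccc2N(Cc2ccccc2Cl)S(=O)(=O)N1Cc1ccccc1Cl`; in a functional assay on MRC5 cells (Homo sapiens) (on this read-out lower numbers stand for higher toxicity in this test and higher numbers for lower toxicity in this test), compound 1 gives 56000 nM.
Compound 2: `O=C1c2ccccc2N(Cc2ccccc2)S(=O)(=O)N1Cc1ccccc1Cl`; in this assay compound 2 gives 60000 nM.
Compound 3: `O=C1c2ccccc2N(Cc2cccc(Cl)c2)S(=O)(=O)N1Cc1ccccc1`; in this assay compound 3 gives 60000 nM.

All three compounds share a core and differ only in the two benzyl groups attached to it. Compounds 2 and 1 differ by a single change, (chloro in place of hydrogen on an aromatic carbon), and the step of a 1.1-fold lower number from compound 2 to compound 1 (0.03 log units; within the scatter) is so small that it lies within the scatter of the test. Compounds 2 and 3 are built from the same atoms joined differently; the difference between the two cores is not broken down here, and their two values show no change at the digits given. Compound 1 sits at the lowest of the three numbers, but every step among them is within the scatter, so no ordering of toxicity can be read from them.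

Compound 4, `O=C1c2ccccc2N(Cc2ccc(Cl)c(Cl)c2)S(=O)(=O)N1Cc1ccccc1`, has not yet been tested. It differs from compound 3 by chloro in place of hydrogen on an aromatic carbon. This is the same kind of change as that from compound 2 to compound 1, though not the same: there the entering chloro sat ortho to a large group, whereas here it sits ortho to a chloro group and para to a large group.

Because the earlier step of a 1.1-fold lower number from compound 2 to compound 1 (0.03 log units; within the scatter) was within the scatter, the step of a 1.1-fold lower number from compound 3 to compound 4 (0.04 log units; within the scatter) is expected to be of similar, negligible size. Compound 4 is therefore estimated to give 55000 nM in this assay, with a range from 30000 nM to 100000 nM expected.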

Compound 4, half-maximal cytotoxic concentration: 56000 nM
Estimate against measurement, compound 4: 1.0-fold (0.01 log units) below; the range from low to high includes it.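

In this assay, the chloro that turns 3-chlorobenzyl into 3,4-dichlorobenzyl gives a 1.1-fold lower number from compound 3 to compound 4 (0.03 log units; within the scatter). Set beside the earlier step, the same replacement reads alike in both settings: the same change on two cores in this assay, a 1.1-fold lower number (0.03 log units; within the scatter) from compound 2 to compound 1 and a 1.1-fold lower number (0.03 log units; within the scatter) from compound 3 to compound 4, 1.0-fold (0.00 log units) apart, within the scatter of two such steps. This shows that in these two pairs, where the entering chloro stands in a different place, the replacement leaves the read-out indistinguishable from that of the starting compound; it does not show that a real effect carries from one core to another, as two steps this small cannot be told apart from no effect at all, and two pairs say nothing about how the replacement would behave on any further core.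

The compounds shown carry only plain or chlorinated benzyl groups, which leaves open how this read-out would respond to a methoxy group, a nitrile or an amine on these rings, or to a longer chain in place of a benzyl group. Going by these compounds, it also remains open whether any change to this series can move the number beyond the scatter of the test.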